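One added methyl on a saturated side chain

A few compounds are considered here, and "the series" means these few. Any claim that something is new, unique, unknown or untested is made for them only; others in the source may bear on it.

In a functional assay on HEL cells (Homo sapiens) (on this read-out higher numbers stand for lower toxicity in this test and lower numbers for higher toxicity in this test), compound 2 (`CCCCCCCCCc1cc2cn(COCCO)c(=O)nc2o1`) stands at >= 100000 nM, which is a limit and not a number. Compound 4 (`CCCCCCCCCCc1cc2cn(COCCO)c(=O)nc2o1`) shares the core of compound 2 and departs from it by a single change: methyl in place of hydrogen on a saturated chain carbon, nine bonds along the chain from an aromatic carbon. In words, this is methyl in place of hydrogen on a saturated chain carbon, nine bonds along the chain from an aromatic carbon.

Compound 1 (`CCCCCCCCCCCc1cc2cn(COCCO)c(=O)nc2o1`) carries ethyl on that same carbon and gives 132000 nM in this assay. Within the data shown here, the one measured step that bears on the change is a step that the limit leaves unreadable from compound 1 to compound 2, so it offers no size to carry over. Among the measured compounds shown here, compound 3 (`CCCCCCCCC#Cc1cc2cn(COCCO)c(=O)nc2o1`), whose chain is not saturated, gives 42000 nM and is linked to compound 2 by no single measured step, so it carries less weight here.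

With hydrogen and ethyl on either side of methyl at this carbon, compound 4 is expected to stay close to the value of compound 1, and it may itself reach the limit. The expected change, a step that the limit leaves unreadable from compound 2 to compound 4, is none beyond the scatter. The estimate for compound 4 is 110000 nM, with an expected range from 50000 nM to 220000 nM.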

Compound 4, half-maximal cytotoxic concentration: > 200000 nM
Compound 4 ended at the assay's limit; the forecaster's own chance of this, stated with the estimate: 45%; middle value at least 1.8-fold (0.25 log units) from the limit.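

Among these compounds, compound 4 gives the first reading for methyl at this saturated chain carbon, and in this assay it rests at a limit and not at a number: the limit of > 200000 nM in this assay, at which 1 of the 4 values shown sits. Set against the ethyl of compound 1, the methyl gives an at least 1.5-fold higher number from compound 1 to compound 4 (0.18 log units; that floor lies within the scatter), and since that floor lies within the scatter, this step alone does not establish a real gap. The steps that involve compound 2 cannot be read, so the data give no size for adding methyl in place of hydrogen at this carbon, and they set no order among the three saturated chains.

As far as these compounds go, it remains open how far the true number of compound 4 lies past its limit, and whether the change from hydrogen to methyl has any measurable size here. Also open, from the compounds shown here alone, is what a saturated chain carrying an amine, or a chain longer than that of compound 1, would give in this assay.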